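Swapping the aryl group on the triazole nitrogen

The compounds below may be only part of what the source reports. "The series", "measured", "known", "first", "only" and "open" are said of these compounds alone.

Measured compounds:
Compound 1 `CC(C)c1ccc(-n2nc(-c3ccc(C(F)(F)F)cc3O)nc2-c2ccccc2O)cc1` gives 100% in a functional assay on PC-12 cells (Rattus norvegicus) for cytotoxicity, read by MTT assay, with stated times of 2 h and 24 h, tested at 5 uM; a higher number here means a stronger effect of the compound at the concentration tested, a lower number a weaker effect.
Compound 2 `Oc1cc(C(F)(F)F)ccc1-c1nc(-c2ccccc2O)n(-c2ccc(Br)cc2)n1` gives 89.8% in this assay.

Compound 1 stands highest of the two measured numbers; the nearest is compound 2, reached by the step of a number 10.2 percentage points lower from compound 1 to compound 2 (beyond the scatter). Compound 3 `Oc1cc(C(F)(F)F)ccc1-c1nc(-c2ccccc2O)n(-c2cccc(F)c2)n1` is unmeasured and differs from compound 1 as follows: 3-fluorophenyl in place of 4-isopropylphenyl on an aromatic nitrogen. For the measured compounds named here, only the step from compound 1 to compound 2 bears on this change, and it was modest. A similar modest drop is therefore expected in this assay for compound 3, shown as a number 12 percentage points lower from compound 1 to compound 3 (beyond the scatter). The estimate for compound 3 is 88%, within 70% to 100%.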

Compound 3, a percentage reported as activity, at one concentration (the size of the read-out at that concentration, not a potency): 87.7%
The estimate for compound 3 lay 0.3 percentage points above the measured number, and the stated range covers the measured number.
By their numbers in this assay, from the lowest: compounds 3 and 2 (each within the scatter of the next); then compound 1.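

Replacing the whole aryl group on this ring nitrogen, rather than a single substituent, still gives only a modest step in this assay (a number 12.3 percentage points lower from compound 1 to compound 3 (beyond the scatter)). The two halogen-bearing groups, 3-fluorophenyl and 4-bromophenyl, cannot be told apart here (a number 2.1 percentage points lower from compound 2 to compound 3 (within the scatter)). Nothing available explains either result.

As far as these compounds go, it remains open whether the higher number of compound 1 depends on the isopropyl group itself. A longer chain, as in 4-butylphenyl, or an amine, as in 4-aminophenyl, on this nitrogen would test that.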